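Benzyloxy in place of methoxy on the oxime of compound 2

The source may report more compounds than this note shows. Statements on the series, on what has been measured and on what is new or still open speak of the compounds shown alone.

Two compounds of the series have numbers in a functional assay on cells (Homo sapiens) for cytotoxicity; on this read-out lower numbers stand for stronger inhibition and higher numbers for weaker inhibition. Compound 1 `CO/N=c1\[nH]cnc2c1[n+](C/C=C(\C)CCC=C(C)C)cn2C` gives 18400 nM. Going by the values given here, compound 2 `CO/N=c1\[nH]cnc2c1[n+](C/C=C(\C)CC/C=C(/C)CCC=C(C)C)cn2C` carries a longer chain on the cationic core and gives 736 nM; the step of a 25-fold lower number from compound 1 to compound 2 (1.40 log units; beyond the scatter) is the only measured step so far. Compound 2 thus holds the lowest of the two numbers, with compound 1 the nearest and higher.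

Compound 3 `CC(C)=CCC/C(C)=C\CC/C(C)=C/C[n+]1cn(C)c2nc[nH]/c(=N\OCc3ccccc3)c21` keeps the chain of compound 2 and changes the oxime ether: phenyl in place of hydrogen on a saturated chain carbon bound to an oxygen. Among the compounds with values here, no measured step touches this part of the molecule; the single step from compound 1 to compound 2 concerns the chain only and gives no direct reading on the oxime ether. The expectation therefore rests on compound 2 alone, with wide uncertainty, and a step no larger than the scatter is expected in either direction, written as a 1.2-fold lower number from compound 2 to compound 3 (0.09 log units; within the scatter). For compound 3 the estimate in this assay is 600 nM, with a range from 150 nM to 2500 nM.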

Compound 3, half-maximal inhibitory concentration: 6760 nM
Compound 3: the middle estimate sits 11-fold (1.05 log units) below what was measured; the whole stated range lies below it.
By their numbers in this assay, from the lowest: compound 2; then compound 3; then compound 1.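

In this assay the change from methoxy to benzyloxy on the oxime, with the chain held as in compound 2, gives a 9.2-fold higher number from compound 2 to compound 3 (0.96 log units; beyond the scatter) and so shows that the oxime ether is a position where the read-out responds, something the earlier pair could not show. The direction is towards weaker inhibition, opposite to the chain extension, which gave a 25-fold lower number from compound 1 to compound 2 (1.40 log units; beyond the scatter) on the same read-out, so the series now has two separate places that each move the number beyond the scatter. Nothing measured here explains why phenyl on the saturated chain carbon bound to an oxygen has this effect.

As far as these compounds go, with a single pair at this position, it remains open whether the shift belongs to the phenyl ring itself or would also come with a plain ethyl or propyl on the oxime oxygen, or whether a free hydroxy there would reverse it. Also open, from the compounds shown here alone, is whether the two changes add up, that is, whether benzyloxy costs the same on the shorter chain of compound 1 as on the longer chain of compound 2.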